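A few compounds are considered here, and "the series" means these few. Any claim that something is new, unique, unknown or untested is made for them only; others in the source may bear on it.

Compound 1 `Cc1c(-c2ccc(-c3ccccc3F)cc2)nc2ccc(F)cc2c1CO` is tested in a functional assay on MOLM-13 cells (Homo sapiens) for antiproliferative activity (a higher number here means a weaker inhibitor, a lower number a stronger inhibitor), where compound 1 gives 700 nM. Among the numbers shown it stands highest; its nearest neighbour is compound 3 `Cc1c(-c2ccc(-c3ccccc3F)cc2)nc2ccc(F)cc2c1C(=O)NS(C)(=O)=O`, which in this assay gives 300 nM, a comparison yielding a 2.3-fold lower number from compound 1 to compound 3 (0.37 log units; beyond the scatter). Compound 2 `Cc1c(-c2ccc(-c3ccccc3F)cc2)nc2ccc(F)cc2c1C(=O)C(F)(F)F` gives > 3000 nM in this assay, a limit of the assay rather than a number. Given (the limit of > 3000 nM in this assay, at which 1 of the 3 values shown sits), the steps of an at least 4.2-fold higher number from compound 1 to compound 2 (0.63 log units; beyond the scatter) and an at least 10-fold lower number from compound 2 to compound 3 (1.00 log units; beyond the scatter) are bounds only. Compound 4 `Cc1c(-c2ccc(-c3ccccc3F)cc2)nc2ccc(F)cc2c1C(=O)NO` has not been measured; it differs from compound 1 by hydroxycarbamoyl in place of hydroxymethyl on an aromatic carbon. Hydroxycarbamoyl is closer in kind to the (methylsulfonyl)carbamoyl of compound 3 than to the (trifluoromethyl)carbonyl of compound 2, so a modest lowering is expected. Compound 4 is estimated at 400 nM in this assay, ranging from 150 nM to 1200 nM. For compound 4 this means an expected 1.8-fold lower number from compound 1 to compound 4 (0.24 log units; within the scatter).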

Compound 4, half-maximal inhibitory concentration: 23 nM
For compound 4 the middle estimate is 17-fold (1.24 log units) above the measured one, and the stated range ends above it.
By their numbers in this assay, from the lowest: compound 4; then compound 3; then compound 1. At a limit, above all of these: compound 2.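

Among these compounds, at this position, on an aromatic carbon opposite the ring nitrogen, hydroxycarbamoyl gives a 30-fold lower number from compound 1 to compound 4 (1.48 log units; beyond the scatter) in this assay, far more than the earlier compounds showed. With the amide-type nitrogen kept, the group on it matters greatly: hydroxy in place of methylsulfonyl gives a 13-fold lower number from compound 3 to compound 4 (1.12 log units; beyond the scatter). The remaining step, an at least 130-fold lower number from compound 2 to compound 4 (2.11 log units; beyond the scatter), is a bound only, and it rests on a limit: the limit of > 3000 nM in this assay, at which 1 of the 4 values shown sits.

The compounds shown leave open how a carboxylic acid, a primary amide or a methoxy group on that nitrogen would compare. Whether the hydroxy itself carries the step therefore stays unsettled.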